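Swapping the azole on the acetamide arm of a chemokine receptor antagonist

The compounds below may be only part of what the source reports. "The series", "measured", "known", "first", "only" and "open" are said of these compounds alone.

Two close relatives share one core and differ only in the small aromatic ring hung on the saturated chain carbon bound to the carbonyl carbon. In a functional assay on CHO-K1 cells for antagonist activity at C-X-C chemokine receptor type 3 (Homo sapiens), read by FLIPR, with a stated time of 10 min (on this read-out higher numbers stand for weaker inhibition and lower numbers for stronger inhibition), compound 1 `CCOc1ncc(-c2nc(C(F)(F)F)sc2N2CCN(C(=O)Cn3cnc4cccnc43)[C@H](C)C2)cn1` gives 2 nM. Within the data shown here, compound 2 `CCOc1ncc(-c2nc(C(F)(F)F)sc2N2CCN(C(=O)Cn3nc(C)cc3C)[C@H](C)C2)cn1` gives 2.3 nM in this assay, which is the higher of the two numbers, with compound 1 as its only neighbour; the pair sits within the scatter, so no order between them can be claimed. Among the measured compounds shown here, the one measured step at this position, a 1.2-fold higher number from compound 1 to compound 2 (0.06 log units; within the scatter), left the number essentially unchanged.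

Compound 3 `CCOc1ncc(-c2nc(C(F)(F)F)sc2N2CCN(C(=O)Cn3cnc(C(F)(F)F)n3)[C@H](C)C2)cn1` carries the same core, with 3-(trifluoromethyl)-1H-1,2,4-triazol-1-yl in place of 3,5-dimethyl-1H-pyrazol-1-yl on a saturated chain carbon bound to a carbonyl carbon. For the measured compounds named here, the single step that bears on this change, a 1.2-fold higher number from compound 1 to compound 2 (0.06 log units; within the scatter), suggests that swapping one small azole for another here moves the number little. A step of about a 1.3-fold higher number from compound 2 to compound 3 (0.12 log units; within the scatter) is therefore expected, not clearly beyond the scatter in either direction. Compound 3 is expected to give about 3 nM in this assay, with a likely range from 1.2 nM to 8 nM.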

Compound 3, half-maximal inhibitory concentration: 3.8 nM
The estimate for compound 3 lay 1.3-fold (0.10 log units) below the measured number, within the range that was stated.
By their numbers in this assay, from the lowest: compounds 1, 2 and 3 (each within the scatter of the next).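

In this assay this position, on a saturated chain carbon bound to a carbonyl carbon, accepts a larger change than the first pair showed: 3-(trifluoromethyl)-1H-1,2,4-triazol-1-yl in place of 3,5-dimethyl-1H-pyrazol-1-yl brings a trifluoromethyl group and a ring with one more hetero atom, yet the result is still only a small step (a 1.7-fold higher number from compound 2 to compound 3 (0.22 log units; within the scatter)). Set against the group of compound 1, which carries a six-membered aromatic ring as well, the triazole group also gives a step inside the scatter (a 1.9-fold higher number from compound 1 to compound 3 (0.28 log units; within the scatter)). No order can therefore be claimed among these three compounds, and for these three groups the number does not separate one ring from another.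

All three groups are aromatic rings joined through a ring nitrogen, so the compounds shown leave open whether the position would accept something of another kind, such as an amine, a carboxylic acid or a longer chain. No measurement at hand accounts for how close these numbers lie.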